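Thiophen-3-yl in place of pyridin-4-yl on the core

The source may hold more compounds than are shown below. What is called first, only, known or untested is meant among the compounds shown, and "the series" means these compounds.

Compound 1 `COc1ccc(Nc2nccc(-c3ccncc3)n2)cc1` gives 4200 nM in a functional assay for inhibition, with Homo sapiens as the target; a lower number here means a stronger inhibitor, a higher number a weaker inhibitor. Among the three measured compounds it stands second highest: compound 2 `CC(=O)N(C)c1ccc(Nc2nccc(-c3ccncc3)n2)cc1` gives 500 nM, and compound 3 `c1cc(-c2ccnc(Nc3ccc(-n4ccnc4)cc3)n2)ccn1` gives 7600 nM. The steps measured so far all alter the group on the aniline ring: an 8.4-fold lower number from compound 1 to compound 2 (0.92 log units; beyond the scatter), a 1.8-fold higher number from compound 1 to compound 3 (0.26 log units; within the scatter) and a 15-fold higher number from compound 2 to compound 3 (1.18 log units; beyond the scatter). Compound 4 `COc1ccc(Nc2nccc(-c3ccsc3)n2)cc1` differs from compound 1 elsewhere: thiophen-3-yl in place of pyridin-4-yl on an aromatic carbon. Within the data shown here, the pyridin-4-yl is kept unchanged in every measured compound, so no measured step bears on this change and the series gives no read on how much that ring contributes or on the size of step to expect. The expectation is therefore a guarded one, with a wide range: a weaker compound 4 is estimated, a 2.1-fold higher number from compound 1 to compound 4 (0.33 log units; beyond the scatter). Compound 4 is expected to give 9000 nM, with a range from 2000 nM to 40000 nM.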

Compound 4, half-maximal inhibitory concentration: 15600 nM
For compound 4 the middle estimate is 1.7-fold (0.24 log units) below the measured one; the range from low to high includes it.
By their numbers in this assay, from the lowest: compound 2; then compounds 1 and 3 (each within the scatter of the next); then compound 4.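

The position carrying pyridin-4-yl is not silent: in this assay, thiophen-3-yl in its place gives a 3.7-fold higher number from compound 1 to compound 4 (0.57 log units; beyond the scatter), the first measured effect of a change outside the group varied in compounds 1 to 3. With methoxy held constant, this six-membered aromatic ring with one ring nitrogen cannot be exchanged for this five-membered aromatic ring with sulfur without a weakening beyond the scatter. No measurement at hand explains the step.

The change alters ring size and hetero atom together, so the compounds shown do not separate the two; phenyl or pyridin-3-yl at this place would bear on that. On these data alone, whether the step holds with the acetyl(methyl)amino group of compound 2 in place of methoxy also stays open.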